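Series notes: bromo to nitro on the phenoxy ring

The source may hold more compounds than are shown below. What is called first, only, known or untested is meant among the compounds shown, and "the series" means these compounds.

Measured in a physicochemical assay for lipophilicity, in phosphate buffer, measured as octanol-water partition, with a stated time of 24 h; a lower number here means a more polar compound, a higher number a more lipophilic compound:
compound 1 `O=C(CSc1nc2ccccc2s1)N/N=C/c1ccc(Oc2ccc(Cl)cc2)cc1`: 5.6
compound 2 `O=C(CSc1nc2ccccc2s1)N/N=C/c1ccc(Oc2ccc3ccccc3c2)cc1`: 5.9
compound 3 `O=C(CSc1nc2ccccc2s1)N/N=C/c1ccc(Oc2ccc(Br)cc2)cc1`: 5.7

Compound 3 stands second highest of the three numbers in this assay; its nearest neighbour is compound 1 a number 0.10 log units higher from compound 1 to compound 3 (within the scatter), its furthest compound 2 a number 0.20 log units lower from compound 2 to compound 3 (within the scatter), so the three measured compounds sit within the scatter of one another. Compound 4 `O=C(CSc1nc2ccccc2s1)N/N=C/c1ccc(Oc2ccc([N+](=O)[O-])cc2)cc1` differs from compound 3 by nitro in place of bromo on an aromatic carbon. Going by the values given here, of the measured steps only a number 0.10 log units higher from compound 1 to compound 3 (within the scatter) changes the same aromatic carbon, and it stayed within the scatter; no measured step brings in a nitro, so the pair is uncovered. For compound 4 a step lower, beyond the scatter, is expected: a number 1.10 log units lower from compound 3 to compound 4 (beyond the scatter). Compound 4 is estimated at 4.6, range 4.1 to 5.1.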

Compound 4, partition coefficient: 5.3
For compound 4 the middle estimate is 0.70 log units below the measured one; measured number outside the range, above it.
By their numbers in this assay, from the lowest: compounds 4, 1, 3 and 2 (each within the scatter of the next, the first and the last beyond it).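

In this assay this aromatic carbon proves able to shift the number, with nitro in place of bromo giving a number 0.40 log units lower from compound 3 to compound 4 (beyond the scatter) where the earlier changes had all stayed within the scatter. The wider change gives a number 0.60 log units lower from compound 2 to compound 4 (beyond the scatter) while a number 0.30 log units lower from compound 1 to compound 4 (within the scatter) does not separate the two compounds, so compound 4 parts clearly only from compound 2 and compound 3.

Going by these compounds, whether an amine or a carboxylic acid on this carbon would go further than nitro stays open. No evidence on the cause of these steps is at hand.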